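Dichloropyridinyl ether switch on the meta-linked isomer

This account rests on a few compounds, and the source may have more. Where it says the series, first, only, none or still open, it means among the compounds named here.

Measured in an assay for inhibition of inositol hexakisphosphate kinase 3 (Homo sapiens), read by colorimetric assay, coupled enzyme assay and malachite green, with a stated time of 120 min, in the presence of a further agent that is not named here; a lower number here means a stronger inhibitor, a higher number a weaker inhibitor:
compound 1, `O=C(O)c1ccc2noc(-c3ccc(Oc4ccccn4)cc3)c2c1`, gives 2060 nM
compound 2, `O=C(O)c1ccc2noc(-c3ccc(Oc4ncc(Cl)cc4Cl)cc3)c2c1`, gives 2250 nM
compound 3, `O=C(O)c1ccc2noc(-c3cccc(Oc4ccccn4)c3)c2c1`, gives 10900 nM

Compound 1 and compound 3 are built from the same atoms joined differently; the difference between the two cores is not broken down here. In this assay compound 3 stands furthest from compound 1 and compound 2, beyond the scatter in each case.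

The change from compound 1 to compound 2 is 3,5-dichloropyridin-2-yl in place of pyridin-2-yl on an oxygen on an aromatic ring. Its step is a 1.1-fold higher number from compound 1 to compound 2 (0.04 log units; within the scatter), so the heavier pyridinyl group left the number essentially unchanged on that core.

Compound 4, `O=C(O)c1ccc2noc(-c3cccc(Oc4ncc(Cl)cc4Cl)c3)c2c1`, is not yet measured. It carries the same kind of change on the core of compound 3: 3,5-dichloropyridin-2-yl in place of pyridin-2-yl on an oxygen on an aromatic ring. Because the earlier step was a 1.1-fold higher number from compound 1 to compound 2 (0.04 log units; within the scatter), compound 4 is expected to sit close to compound 3, with an estimated step of a 1.1-fold higher number from compound 3 to compound 4 (0.04 log units; within the scatter). The estimate for compound 4 in this assay is 12000 nM, with a likely range from 5000 nM to 30000 nM. This rests on a single precedent pair, so the range is kept wide.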

Compound 4, half-maximal inhibitory concentration: 3090 nM
Compound 4: middle estimate off by 3.9-fold (0.59 log units), on the high side, and the stated range ends above it.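

In this assay the change from pyridin-2-yl to 3,5-dichloropyridin-2-yl on the oxygen gives a 3.5-fold lower number from compound 3 to compound 4 (0.55 log units; beyond the scatter), so its size differs between the two cores and does not transfer as a constant increment: the same change on two cores in this assay, a 1.1-fold higher number (0.04 log units; within the scatter) from compound 1 to compound 2 and a 3.5-fold lower number (0.55 log units; beyond the scatter) from compound 3 to compound 4, 3.9-fold (0.59 log units) apart, beyond the scatter of two such steps

For this series, the step measured on the core of compound 1 is therefore a poor guide to the same change on the core of compound 3, and any read-across between these cores needs a measurement on each. Going by these compounds alone, with only two matched pairs, this shows that the change depends on the core in these compounds, but it neither explains that dependence nor sets a rule for other cores or other ether groups.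

Going by these compounds, it remains open whether a pyridin-2-yl carrying a single chlorine would account for the step on the core of compound 3, or whether both chlorines are needed. Also open, on these data alone, is whether a nitrile or a methoxy group in place of chlorine, or an amide in place of the carboxylic acid, would show the same dependence on the core.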